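Bromo for 1H-imidazol-4-yl in a set at the limit

A few compounds are considered here, and "the series" means these few. Any claim that something is new, unique, unknown or untested is made for them only; others in the source may bear on it.

Measured so far in a functional assay on HeLa cells (Homo sapiens) for inhibition, read by MTT assay, with a stated time of 72 h; on this read-out lower numbers stand for stronger inhibition and higher numbers for weaker inhibition (each value is a limit of the assay, not a number):
Compound 1 `COc1cc(OC)c(-c2cc(=O)c3ccc(O)cc3o2)cc1OC` gives > 150000 nM as a limit
Compound 2 `COc1cc(OC)c(OC)cc1/C=C/C(=O)c1ccc(-c2c[nH]cn2)cc1` gives > 150000 nM as a limit
Compound 3 `COc1cc(OC)c(OC)cc1/C=C/C(=O)c1cccc(C(F)(F)F)c1` gives > 150000 nM as a limit

Going by the values given here, the picture for the set is the limit of > 150000 nM in this assay, at which 3 of the 3 values shown sit, and no order among the compounds follows from it. Compound 2 therefore has no exact position, only a limit shared with the others.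

The next compound is compound 4 `COc1cc(OC)c(OC)cc1/C=C/C(=O)c1ccc(Br)cc1` and it differs from compound 2 in one place: bromo in place of 1H-imidazol-4-yl on an aromatic carbon. In words, this is bromo in place of 1H-imidazol-4-yl on an aromatic carbon, para to a large group.

Among the compounds with values here, no measured pair shows what a change like this does, so any expectation here is a cautious one. Compound 3 also carries no 1H-imidazol-4-yl group and still gives > 150000 nM as a limit. In this assay only a modest move towards stronger inhibition is therefore expected, and possibly none beyond the scatter. The estimated change is an at least 1.5-fold lower number from compound 2 to compound 4 (0.17 log units; that floor lies within the scatter) and the assay may again report only a limit. For compound 4 the expected value is 100000 nM with 25000 nM to 200000 nM as the estimated range.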

Compound 4, half-maximal inhibitory concentration: 31700 nM
Compound 4: middle estimate off by 3.2-fold (0.50 log units), on the high side; the range from low to high includes it.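

In this assay, bromo in place of 1H-imidazol-4-yl on an aromatic carbon, para to a large group, gives an at least 4.7-fold lower number from compound 2 to compound 4 (0.67 log units; beyond the scatter). Going by these compounds alone, this is the first step in the set that can be read at all, and it shows that the group on this carbon can move the read-out beyond the scatter, with compound 4 giving a real number rather than a limit. The true size of the step stays unknown, and the printed figure is only a floor, because compound 2 has no exact value of its own: the limit of > 150000 nM in this assay, at which 3 of the 4 values shown sit.

The compounds shown do not separate what bromo itself contributes from what the loss of 1H-imidazol-4-yl contributes, since a single pair changes both at once. As far as these compounds go, what a chloro, a methoxy, an amine or a carboxylic acid would do on this same carbon remains open, and so does whether any of them would give a lower number than bromo or fall back to the limit.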